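The source may hold more compounds than are shown below. What is called first, only, known or untested is meant among the compounds shown, and "the series" means these compounds.

Measured in a functional assay on G-361 cells (Homo sapiens) for inhibition, with a stated time of 72 h; a lower number here means a stronger inhibitor, a higher number a weaker inhibitor:
- compound 1 `NC1CCC(Nc2nc(NCc3ccc(-c4cccc(F)c4)cc3)c3ncn(C4CCCC4)c3n2)CC1`: 815 nM
- compound 2 `NC1CCC(Nc2nc(NCc3ccc(-c4ccco4)cc3)c3ncn(C4CCCC4)c3n2)CC1`: 164 nM
- compound 3 `CC(C)(O)CNc1nc(NCc2ccc(-c3ccco3)cc2)c2ncn(C3CCCC3)c2n1`: 17400 nM

Compound 2, at 164 nM, has the lowest number of the three, which makes it the strongest inhibitor so far. Compound 4 `NC1CCC(Nc2nc(NCc3ccc(-c4ccsc4)nc3)c3ncn(C4CCCC4)c3n2)CC1` keeps the 4-aminocyclohexyl group of compound 2 but changes the group on a saturated chain carbon bound to a nitrogen on an aromatic ring: 6-(thiophen-3-yl)pyridin-3-yl in place of 4-(furan-2-yl)phenyl on a saturated chain carbon bound to a nitrogen on an aromatic ring.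

Two measured steps can be weighed. The more relevant one is a 5.0-fold lower number from compound 1 to compound 2 (0.70 log units; beyond the scatter), a modest step from placing furan-2-yl in the position of 3-fluorophenyl. The other, a 110-fold higher number from compound 2 to compound 3 (2.03 log units; beyond the scatter), is large, but it replaces the 4-aminocyclohexyl group, which compound 4 retains. For the measured compounds named here, no measured compound carries thiophen-3-yl or pyridin-3-yl, so the data show no direction. A step no larger than that modest one is therefore expected in this assay. The estimated change is a 1.5-fold higher number from compound 2 to compound 4 (0.18 log units; within the scatter). The estimate for compound 4 is 250 nM, with an expected range of 80 nM to 800 nM.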

Compound 4, half-maximal inhibitory concentration: 272 nM
For compound 4 the middle estimate is 1.1-fold (0.04 log units) below the measured one, within the range that was stated.
By their numbers in this assay, from the lowest: compounds 2 and 4 (each within the scatter of the next); then compound 1; then compound 3.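

Placing 6-(thiophen-3-yl)pyridin-3-yl in position of 4-(furan-2-yl)phenyl in this assay gives a 1.7-fold higher number from compound 2 to compound 4 (0.22 log units; within the scatter) and so leaves no change that can be told from the scatter, even though both aromatic rings of the group differ at once. This position, on a saturated chain carbon bound to a nitrogen on an aromatic ring, therefore tolerates a group with a nitrogen in the six-membered ring and sulfur in place of oxygen in the five-membered ring, at the same count of heavy atoms. Nothing measured here explains why the number moves so little.

The effects of the two ring changes cannot be separated, and they might offset each other. As far as these compounds go, how a carboxylic acid or an amine in place of thiophen-3-yl would fare remains open.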